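This account rests on a few compounds, and the source may have more. Where it says the series, first, only, none or still open, it means among the compounds named here.

Compound 1 `CCOC(=O)Cn1ncc2c(Nc3ccc(NC(=O)CCl)cc3)ncnc21` and compound 2 `CCOC(=O)Cn1ncc2c(Nc3ccc(NC(=O)c4ccccc4)cc3)ncnc21` share a core and differ in chloromethyl in place of phenyl on a carbonyl carbon. In a functional assay on cells (Homo sapiens) for inhibition, read by MTT assay, with a stated time of 72 h (on this read-out lower numbers stand for stronger inhibition and higher numbers for weaker inhibition), compound 1 gives 7.27 ug/mL. For compound 2 this assay reports only a limit, > 100 ug/mL. The step is an at least 13-fold lower number from compound 2 to compound 1 (1.13 log units; beyond the scatter). Compound 3 `O=C(O)Cn1ncc2c(Nc3ccc(NC(=O)c4ccccc4)cc3)ncnc21` differs from compound 2 in hydrogen in place of ethyl on an oxygen next to a carbonyl group; for compound 3 this assay again reports only a limit, > 100 ug/mL, so the step that the two limits leave unreadable from compound 2 to compound 3 is unreadable, as two of the three values sit at the limit (the limit of > 100 ug/mL in this assay, at which 2 of the 3 values shown sit). Compound 4 `O=C(O)Cn1ncc2c(Nc3ccc(NC(=O)CCl)cc3)ncnc21` differs from compound 3 in chloromethyl in place of phenyl on a carbonyl carbon, the same change as from compound 2 to compound 1 at the same place. For compound 4 an analogous step an at least 5.0-fold lower number from compound 3 to compound 4 (0.69 log units; beyond the scatter) is expected, resting on the measured step of an at least 13-fold lower number from compound 2 to compound 1 (1.13 log units; beyond the scatter) and the value of compound 1 7.27 ug/mL. Compound 4 is estimated at 20 ug/mL, between 5 ug/mL and 100 ug/mL.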

Compound 4, half-maximal inhibitory concentration: > 100 ug/mL
Compound 4: only a limit was reported (the forecaster's own chance of this, stated with the estimate: 25%); middle value at least 5.0-fold (0.69 log units) from the limit.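

In this assay compound 4 gives only a limit, > 100 ug/mL. With chloromethyl kept, hydrogen in place of ethyl gives an at least 13-fold higher number from compound 1 to compound 4 (1.13 log units; beyond the scatter), so the drop seen for chloromethyl in place of phenyl on the core of compound 2 does not reappear as a readable step on the core of compound 3. The steps between compounds at the limit cannot be read, so the data do not show whether the change has any effect on that core, only that no carry-over can be seen: the limit of > 100 ug/mL in this assay, at which 3 of the 4 values shown sit.

Going by these compounds, it remains open whether the lower number of compound 1 would hold with an aminomethyl group or a longer chain on the carbonyl carbon. Also open, on these data alone, is how a primary amide in place of the carboxylic acid would read in this assay.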